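The source may report more compounds than this note shows. Statements on the series, on what has been measured and on what is new or still open speak of the compounds shown alone.

Of the compounds shown here, three that share one core have been measured in a functional assay on SW-620 cells (Homo sapiens) for cytotoxicity, read by MTT assay, with stated times of 4 h and 72 h, tested at 5 uM; a lower number here means a stronger inhibitor, a higher number a weaker inhibitor. Compound 1 `Cc1cc(Nc2ccc(C(=O)/C=C/c3ccc4ccccc4c3)cc2)n2nc(SCc3ccc([N+](=O)[O-])cc3)nc2n1` gives 1130 nM. Compound 2 `Cc1cc(Nc2ccc(C(=O)/C=C/c3ccc4ccccc4c3)cc2)n2nc(SCc3ccc(F)cc3)nc2n1` gives 320 nM, and compound 3 `Cc1cc(Nc2ccc(C(=O)/C=C/c3ccc4ccccc4c3)cc2)n2nc(SCc3cccc(Br)c3)nc2n1` gives 270 nM, the lowest of the three numbers, though its gap to compound 2 lies within the scatter, so the two cannot be ranked against each other. Only the gap to compound 1 is beyond the scatter, as a 4.2-fold lower number from compound 1 to compound 3 (0.62 log units; beyond the scatter) shows, alongside a 3.5-fold lower number from compound 1 to compound 2 (0.55 log units; beyond the scatter). Compound 4 `Cc1cc(Nc2ccc(C(=O)/C=C/c3ccc4ccccc4c3)cc2)n2nc(SCc3ccccc3Br)nc2n1` has not yet been measured. It differs from compound 3 in a single place: 2-bromophenyl in place of 3-bromophenyl on a saturated chain carbon bound to a sulfur. The measured step that bears most on this is a 1.2-fold lower number from compound 2 to compound 3 (0.07 log units; within the scatter), in which one halogen-bearing phenyl replaced another and the number stayed within the scatter. Replacing 3-bromophenyl with 2-bromophenyl is expected to behave in the same way, so the expected step of a 1.1-fold higher number from compound 3 to compound 4 (0.05 log units; within the scatter) is none beyond the scatter. Compound 4 is therefore estimated to give 300 nM, within a range from 130 nM to 700 nM.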

Compound 4, half-maximal inhibitory concentration: 420 nM
Beside the measured number, compound 4's estimate is 1.4-fold (0.15 log units) below it, and the stated range covers the measured number.
By their numbers in this assay, from the lowest: compounds 3, 2 and 4 (each within the scatter of the next); then compound 1.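

In this assay, 2-bromophenyl in place of 3-bromophenyl on the saturated chain carbon bound to a sulfur gives a 1.6-fold higher number from compound 3 to compound 4 (0.19 log units; within the scatter) so these two bromine placements cannot be told apart by this read-out. The same holds against the 4-fluorophenyl group, with a 1.3-fold higher number from compound 2 to compound 4 (0.12 log units; within the scatter) while a 2.7-fold lower number from compound 1 to compound 4 (0.43 log units; beyond the scatter) shows that compound 4 joins compound 2 and compound 3 in standing apart from the 4-nitrophenyl compound. No measurement is available that would explain these differences.

Going by these compounds, whether 4-bromophenyl would also fall with these three compounds remains open. So does the outcome of placing an amine or a carboxylic acid on this phenyl ring, or of a longer chain on the sulfur in place of the benzyl group.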